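Ester chain lengthening on the dihydropyridine core

The source may report more compounds than this note shows. Statements on the series, on what has been measured and on what is new or still open speak of the compounds shown alone.

Compound 1 `CCOC(=O)C1=C(C)NC(C)=C(C(=O)OCC)C1c1csc(-c2ccc(Cl)cc2)n1`: 3650 nM
Compound 2 `CCOC(=O)C1=C(C)NC(C)=C(C(=O)OC)C1c1csc(-c2ccc(Cl)cc2)n1`: 22000 nM
Compound 3 `COC(=O)C1=C(C)NC(C)=C(C(=O)OC2CCCCC2)C1c1csc(-c2ccc(Cl)cc2)n1`: 71900 nM

Three compounds sharing one core were measured in an assay on isolated protein for antagonist activity at Voltage-dependent L-type calcium channel subunit alpha-1C (Cavia porcellus), with a stated time of 15 min; a higher number here means a weaker inhibitor, a lower number a stronger inhibitor. In this assay compound 1 gives 3650 nM, compound 2 gives 22000 nM and compound 3 gives 71900 nM; compound 3 stands highest of the three, with a 3.3-fold higher number from compound 2 to compound 3 (0.51 log units; beyond the scatter) separating it from its nearest neighbour compound 2, and compound 1 lies furthest from it.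

Two single changes link the measured compounds. From compound 2 to compound 1 the change is methyl in place of hydrogen on a saturated chain carbon bound to an oxygen next to a carbonyl group, and it gave a 6.0-fold lower number from compound 2 to compound 1 (0.78 log units; beyond the scatter). From compound 2 to compound 3 the change is cyclohexyl in place of ethyl on an oxygen next to a carbonyl group, and it gave a 3.3-fold higher number from compound 2 to compound 3 (0.51 log units; beyond the scatter).

Compound 4 `CCOC(=O)C1=C(C)NC(C)=C(C(=O)OC2CCCCC2)C1c1csc(-c2ccc(Cl)cc2)n1` has not yet been measured. It differs from compound 3 by methyl in place of hydrogen on a saturated chain carbon bound to an oxygen next to a carbonyl group, the same change that was made from compound 2 to compound 1. The place of the change is worded identically in both pairs; the two cores differ in the way described by cyclohexyl in place of ethyl on an oxygen next to a carbonyl group. This change occurs twice among the compounds shown, and its only measured instance is the step from compound 2 to compound 1.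

Because a 6.0-fold lower number from compound 2 to compound 1 (0.78 log units; beyond the scatter) lowered the number when this change was made once before, compound 4 is expected to show a lower number than compound 3, an expected step of a 4.8-fold lower number from compound 3 to compound 4 (0.68 log units; beyond the scatter). Resting on that single precedent, and allowing that a step seen once on one core need not repeat in full on another, compound 4 is estimated at 15000 nM, expected to fall between 5000 nM and 50000 nM.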

Compound 4, half-maximal inhibitory concentration: 100000 nM
For compound 4 the middle estimate is 6.7-fold (0.82 log units) below the measured one, and the stated range ends below it.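

In this assay, methyl in place of hydrogen on a saturated chain carbon bound to an oxygen next to a carbonyl group gave a 1.4-fold higher number from compound 3 to compound 4 (0.14 log units; within the scatter), so the gain seen on the core of compound 2 did not carry over to the core of compound 3, and the two instances differ: the same change on two cores in this assay, a 6.0-fold lower number (0.78 log units; beyond the scatter) from compound 2 to compound 1 and a 1.4-fold higher number (0.14 log units; within the scatter) from compound 3 to compound 4, 8.4-fold (0.92 log units) apart, beyond the scatter of two such steps

The cyclohexyl change depends on the core in the same way, as cyclohexyl in place of methyl gave a 4.5-fold higher number from compound 2 to compound 4 (0.66 log units; beyond the scatter), while cyclohexyl in place of ethyl gave a 27-fold higher number from compound 1 to compound 4 (1.44 log units; beyond the scatter), which stands well apart from the earlier step: the same change on two cores in this assay, a 3.3-fold higher number (0.51 log units; beyond the scatter) from compound 2 to compound 3 and a 27-fold higher number (1.44 log units; beyond the scatter) from compound 1 to compound 4, 8.4-fold (0.92 log units) apart, beyond the scatter of two such steps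

For the compounds shown here, these four compounds show that a step measured on one core could not be carried to the other here, but they do not show why, and with only two cores they say nothing about how the change would behave on any further core.

Going by these compounds, it remains open whether a longer chain such as propyl on the ester would extend the gain seen with ethyl on the core of compound 2. On these data alone, it also remains open whether a smaller ring such as cyclopentyl would keep the ethyl step intact.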